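The compounds below may be only part of what the source reports. "The series", "measured", "known", "first", "only" and "open" are said of these compounds alone.

Compound 1 `Cc1ccccc1Cc1cnc(CCc2ccc(-c3ccccc3C(=O)O)cc2)[nH]1`: 127 nM. Compound 2 `N#Cc1ccc(Cc2cnc(CCc3ccc(-c4ccccc4C(=O)O)cc3)[nH]2)cc1`: 5890 nM.

In an in vitro functional assay on cells for agonist activity at Bombesin receptor subtype-3 (Homo sapiens), read by luminescence and calcium flux (a lower number here means that less compound is needed, a higher number that more compound is needed for the effect), compound 2 gives the highest of the two numbers, and its nearest neighbour is compound 1, separated by the step of a 46-fold higher number from compound 1 to compound 2 (1.67 log units; beyond the scatter). Compound 3 `O=C(O)c1ccccc1-c1ccc(CCc2ncc(CCC3CCCCC3)[nH]2)cc1` differs from compound 2 by cyclohexylmethyl in place of 4-cyanophenyl on a saturated chain carbon bound to an aromatic carbon. Among the measured compounds shown here, the one measured step at this place, a 46-fold higher number from compound 1 to compound 2 (1.67 log units; beyond the scatter), was a large rise when 4-cyanophenyl replaced 2-methylphenyl; now that group leaves again, and its nitrile with it, though a saturated ring has not been tried here. A fall is therefore expected, a 9.8-fold lower number from compound 2 to compound 3 (0.99 log units; beyond the scatter), with a wide margin. Compound 3 is estimated at 600 nM, within 120 nM to 3000 nM.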

Compound 3, half-maximal effective concentration: 642 nM
Compound 3: the middle estimate sits 1.1-fold (0.03 log units) below what was measured, within the range that was stated.
By their numbers in this assay, from the lowest: compound 1; then compound 3; then compound 2.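

In this assay the step of a 9.2-fold lower number from compound 2 to compound 3 (0.96 log units; beyond the scatter) shows that a group without an aromatic ring or nitrile can still give a response at this place on the saturated chain carbon. Even so, 2-methylphenyl stays ahead, as the step of a 5.1-fold higher number from compound 1 to compound 3 (0.70 log units; beyond the scatter) makes plain. Nothing available explains either step.

The ring and the chain length change together here, from 4-cyanobenzyl to 2-cyclohexylethyl, so their separate contributions cannot be read. As far as these compounds go, how an unsubstituted benzyl group or a 2-phenylethyl chain would compare remains open.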